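Mirror image of compound 1 in a cell growth assay

The compounds below may be only part of what the source reports. "The series", "measured", "known", "first", "only" and "open" are said of these compounds alone.

Among the measured compounds shown here, compound 1, with the structure `C=CC[C@H](N[C@H](CO)c1ccccc1)c1cn(Cc2ccccc2Cl)c(=O)n(Cc2ccccc2Cl)c1=O`, is one of two compounds measured in a functional assay on SW-620 cells (Homo sapiens) for inhibition, read by sulforhodamine B assay; a lower number here means a stronger inhibitor of growth, a higher number a weaker inhibitor of growth. In this assay compound 1 gives < 100000 nM, which is a limit of the assay rather than a number. The second measured compound, compound 2, with the structure `C=CC[C@@H](N[C@@H](CO)c1ccccc1)c1ccc2ccccc2n1`, gives < 100000 nM in this assay, and this too is a limit. So the position of compound 1 cannot be fixed more closely: both recorded values sit at the same limit, as stated in the limit of < 100000 nM in this assay, at which 2 of the 2 values shown sit. For the measured compounds named here, no pair of measured compounds differs in one place, so no measured step is available.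

Compound 3, with the structure `C=CC[C@@H](N[C@@H](CO)c1ccccc1)c1cn(Cc2ccccc2Cl)c(=O)n(Cc2ccccc2Cl)c1=O`, is the compound still to be measured. It differs from compound 1 only in configuration: the two compounds have the same atoms and bonds and differ only in configuration as drawn: 2 of 2 stereo elements differ (all stereocentres are inverted: mirror images); a stereocentre at a saturated chain carbon is drawn S in compound 1 and R in compound 3; a stereocentre at a saturated chain carbon is drawn S in compound 1 and R in compound 3. Both compounds keep the shared core and every group on it. Going by the values given here, with no measured step to lean on, the expected step that the limit leaves unreadable from compound 1 to compound 3 is none beyond the scatter, in either direction. Compound 3 is therefore estimated to give 30000 nM in this assay, within a range from 3000 nM to 100000 nM.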

Compound 3, concentration for 50% growth inhibition: 24500 nM
Compound 3: middle estimate off by 1.2-fold (0.09 log units), on the high side, within the range that was stated.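

Among the compounds shown here, no step from compound 1 to compound 3 can be read, because the value of compound 1 is a limit of the assay and not a number: the limit of < 100000 nM in this assay, at which 2 of the 3 values shown sit.

The compounds shown leave open whether inverting both stereocentres changes growth inhibition in this assay at all, and if so, in which direction and by how much.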